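The compounds below may be only part of what the source reports. "The series", "measured", "known", "first", "only" and "open" are said of these compounds alone.

Compound 3 `Fc1cccc(F)c1C1CCN(Cc2ccn3c(CC4CC4)nnc3c2C(F)(F)F)CC1` gives 9.7 nM in an assay on CHO cells for positive allosteric modulation of metabotropic glutamate receptor 2 (Homo sapiens), read by scintillation counting, with a stated time of 30 min (on this read-out lower numbers stand for an effect already at smaller amounts and higher numbers for an effect only at larger amounts of compound), the low end of the three numbers: the step of a 2.2-fold lower number from compound 1 to compound 3 (0.34 log units; beyond the scatter) sets it apart from compound 1 `FC(F)(F)c1c(CN2CCC(c3ccccc3)CC2)ccn2c(CC3CC3)nnc12` at 21 nM, whereas the step of a 1.5-fold lower number from compound 2 to compound 3 (0.19 log units; within the scatter) leaves it level with compound 2 `Fc1ccccc1C1CCN(Cc2ccn3c(CC4CC4)nnc3c2C(F)(F)F)CC1` at 15 nM. Compound 4 `Fc1ccc(C2CCN(Cc3ccn4c(CC5CC5)nnc4c3C(F)(F)F)CC2)c(F)c1` carries the change (2,4-difluorophenyl in place of 2,6-difluorophenyl on a saturated ring carbon). Among the compounds with values here, the measured steps add fluoro, a 1.4-fold lower number from compound 1 to compound 2 (0.15 log units; within the scatter) and a 1.5-fold lower number from compound 2 to compound 3 (0.19 log units; within the scatter), both small; none moves a fluoro from one place to another, so no measured step bears directly on this change. With the same atoms joined differently and only small steps across the series, compound 4 is expected to stay close to compound 3, with the estimated step of a 1.4-fold higher number from compound 3 to compound 4 (0.16 log units; within the scatter) in this assay. Compound 4 is estimated at 14 nM, within 6 nM to 35 nM.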

Compound 4, half-maximal effective concentration: 15 nM
Estimate against measurement, compound 4: 1.1-fold (0.03 log units) below, within the range that was stated.
By their numbers in this assay, from the lowest: compounds 3, 2, 4 and 1 (each within the scatter of the next, the first and the last beyond it).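

Moving a fluoro on the phenyl at this saturated ring carbon gives a 1.5-fold higher number from compound 3 to compound 4 (0.19 log units; within the scatter) in this assay, so 2,6-difluorophenyl and 2,4-difluorophenyl are not told apart here. The second fluoro of 2,4-difluorophenyl gives no change at the digits printed from compound 2 to compound 4 (within the scatter), and the full change from phenyl gives a 1.4-fold lower number from compound 1 to compound 4 (0.15 log units; within the scatter), so neither step separates the compounds. No data on hand account for these small steps. Open, as far as these compounds go, is how a chloro or methoxy group on this phenyl, or an amine in its place, would compare with the fluoro compounds.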